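The source may report more compounds than this note shows. Statements on the series, on what has been measured and on what is new or still open speak of the compounds shown alone.

Three measured compounds:
compound 1, `N=c1oc2ccc(Br)cc2cc1C(=O)NC1CCCCC1`, 8%;
compound 2, `CCC(CO)NC(=O)c1cc2cccc(OC)c2oc1=N`, 6%;
compound 3, `COc1cccc2cc(C(=O)NC3CCCCC3)c(=N)oc12`, 16%.

All three were tested in an assay on HeLa cells for displacement of a labelled ligand from adenosine receptor A3 (Homo sapiens), read by scintillation counting, with a stated time of 180 min, tested at 10 uM; a lower number here means less inhibition, a higher number more inhibition at the concentration tested (going by the name of the read-out). Compound 3 and compound 2 share a core and differ in one place: 1-(hydroxymethyl)propyl in place of cyclohexyl on an amide-type nitrogen. That change gave a number 10 percentage points lower from compound 3 to compound 2 (within the scatter). Compound 1 carries a different core; how its core differs from that of compound 3 is not broken down here, and the two values simply stand close together. Compound 4, `CCC(CO)NC(=O)c1cc2cc(Br)ccc2oc1=N`, is not yet measured. It arises from compound 1 by the same change at the same place, (1-(hydroxymethyl)propyl in place of cyclohexyl on an amide-type nitrogen). Because the earlier step of that change was a number 10 percentage points lower from compound 3 to compound 2 (within the scatter), compound 4 is expected to show a similar small step, a number 4 percentage points lower from compound 1 to compound 4 (within the scatter). In this assay compound 4 is estimated to give about 4%, expected between -6% and 14%.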

Compound 4, a percentage reported as inhibition, at one concentration (the size of the read-out at that concentration, not a potency): 24%
For compound 4 the middle estimate is 20 percentage points below the measured one, outside the stated range (above it).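

Putting 1-(hydroxymethyl)propyl in place of cyclohexyl on an amide-type nitrogen gave a number 16 percentage points higher from compound 1 to compound 4 (beyond the scatter) in this assay. The same change therefore did not carry over as one fixed step from one core to the other: the same change on two cores in this assay, a number 10 percentage points lower (within the scatter) from compound 3 to compound 2 and a number 16 percentage points higher (beyond the scatter) from compound 1 to compound 4, 26 percentage points apart, beyond the scatter of two such steps

Among these compounds, with only two pairs, this shows that the core matters for this change here, but not which difference between the cores is responsible or how the change would behave on a third core. Still open, as far as these compounds go, is whether an amine, a carboxylic acid or a longer chain at that amide-type nitrogen would also give steps that differ between these two cores.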